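The source may report more compounds than this note shows. Statements on the series, on what has been measured and on what is new or still open speak of the compounds shown alone.

Of the compounds shown here, three built on one shared core have been tested in an ADME assay on microsomes from liver (Homo sapiens) for metabolic stability, read by LC-MS, with a stated time of 15 min, tested at 1 uM, in the presence of a further agent that is not named here; on this read-out higher numbers stand for a more stable compound and lower numbers for a less stable compound. Compound 1 `CC(C)n1nc(-c2ccc3oc(N)nc3c2)c2c(C#N)nc(N)nc21` carries a cyano group on its core. In this assay compound 1 gives > 95%, which is a limit of the assay and not a number. Compound 2 `CC(C)n1nc(-c2ccc3oc(N)nc3c2)c2c(N)nc(N)nc21` has an amino group in place of that cyano. In this assay compound 2 gives > 95%, again a limit rather than a number. The step from compound 1 to compound 2 is therefore a step that the two limits leave unreadable from compound 1 to compound 2. Compound 3 `CC(C)n1nc(-c2ccc3oc(N)nc3c2)c2c(=O)[nH]c(N)nc21` carries a carbonyl on its core instead. In this assay compound 3 gives > 95%, which is a limit and not a number. Compound 3 thus stands where every measured compound stands, because of the limit of > 95% in this assay, at which 3 of the 3 values shown sit. Compound 4 `CNc1nc2c(c(-c3ccc4oc(N)nc4c3)nn2C(C)C)c(=O)[nH]1` differs from compound 3 by methyl in place of hydrogen on a nitrogen on an aromatic ring. Within the data shown here, no measured step covers this change, and the only step measured at all is unreadable. The step from compound 3 to compound 4 is expected to be a number at least 5 percentage points lower from compound 3 to compound 4 (that floor lies within the scatter), within the scatter. Compound 4 is expected to give 90%, between 75% and 99%.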

Compound 4, percent of the compound remaining: > 95%
Compound 4 gave a limit, no number (the forecaster's own chance of this, stated with the estimate: 55%); middle value at least 5 percentage points from the limit.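

Among these compounds, compound 4 also sits at a limit of the assay rather than a number, so no step from compound 3 to compound 4 can be read, because both values are limits: the limit of > 95% in this assay, at which 4 of the 4 values shown sit. The compounds shown leave open whether compound 1, compound 2, compound 3 and compound 4 differ at all in this assay, and what any change on the shared core does there.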